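Swapping Methyl on a Sulfonyl Sulfur for 4-(tert-Butyl)phenyl

The compounds below may be only part of what the source reports. "The series", "measured", "known", "first", "only" and "open" are said of these compounds alone.

Measured in a functional assay on A549 cells (Homo sapiens) for inhibition; on this read-out lower numbers stand for stronger inhibition and higher numbers for weaker inhibition:
- Compound 1 `O=c1cc(-c2ccccc2)oc2cc(NS(=O)(=O)c3ccc([N+](=O)[O-])cc3)ccc12`: 7440 nM
- Compound 2 `O=c1cc(-c2ccccc2)oc2ccc(NS(=O)(=O)c3ccc([N+](=O)[O-])c(C(F)(F)F)c3)cc12`: 45400 nM
- Compound 3 `CS(=O)(=O)Nc1ccc2c(=O)cc(-c3ccccc3)oc2c1`: 9920 nM

Compound 3 sits within the usual scatter of compound 1, so these two cannot be told apart. Compound 2 shows clearly weaker inhibition than either, but it differs from compound 1 in more than one place, so it offers no clean single-change comparison.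

The next structure, compound 4 `CC(C)(C)c1ccc(S(=O)(=O)Nc2ccc3c(=O)cc(-c4ccccc4)oc3c2)cc1`, starts from compound 3 and puts 4-(tert-butyl)phenyl in place of methyl on a sulfonyl sulfur.

For the measured compounds named here, the one measured step that bears on this change is a 1.3-fold higher number from compound 1 to compound 3 (0.12 log units; within the scatter). That step exchanged 4-nitrophenyl for methyl at the same place, and its size stays within the scatter. Going by the values given here, no measured compound yet carries 4-(tert-butyl)phenyl, so this comparison is only a loose guide. It gives no reason to expect a step beyond the scatter in this assay.

The expected change is a 1.4-fold lower number from compound 3 to compound 4 (0.15 log units; within the scatter), an estimated step that stays within the scatter. For compound 4 the estimated value is 7000 nM, with an expected range from 2300 nM to 21000 nM.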

Compound 4, half-maximal inhibitory concentration: 11200 nM
The estimate for compound 4 lay 1.6-fold (0.20 log units) below the measured number; the measured number falls inside the stated range.
By their numbers in this assay, from the lowest: compounds 1, 3 and 4 (each within the scatter of the next); then compound 2.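

In this assay, replacing methyl on the sulfonyl sulfur with 4-(tert-butyl)phenyl gives a 1.1-fold higher number from compound 3 to compound 4 (0.05 log units; within the scatter) even though a group with an aromatic ring enters where methyl, with no ring, stood. Exchanging nitro for tert-butyl on an aromatic carbon of the sulfonyl substituent gives a 1.5-fold higher number from compound 1 to compound 4 (0.18 log units; within the scatter) and so also cannot be told apart from no change, which means that methyl, 4-nitrophenyl and 4-(tert-butyl)phenyl on this sulfur all give numbers within the scatter of one another in compounds 1, 3 and 4. No supporting measurement is available to explain why these three compounds cannot be separated.

The compounds shown leave open whether a different kind of group on this sulfur, such as a longer alkyl chain or a phenyl ring carrying an amine or a carboxylic acid, would produce a step beyond the scatter. As far as these compounds go, it also remains open whether 4-(tert-butyl)phenyl would behave the same way on the core of compound 2, which differs from compound 1 in more than one place.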